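The source may hold more compounds than are shown below. What is called first, only, known or untested is meant among the compounds shown, and "the series" means these compounds.

In a functional assay on P388 cells (Mus musculus) for inhibition, with a stated time of 48 h (on this read-out higher numbers stand for weaker inhibition and lower numbers for stronger inhibition), compound 1 `COC(=O)C1CSC(c2ccccc2O)=N1` gives 18000 nM. Compound 2 `O=C(NCCCCN(CCCCNC(=O)C1CSC(c2ccccc2O)=N1)Cc1ccccc1)C1CSC(c2ccccc2O)=N1` gives 1000 nM in this assay. This is the lower of the two numbers, and its gap to compound 1 lies beyond the scatter, so compound 2 is the stronger inhibitor of the pair. Among the compounds with values here, these two compounds differ in more than one place, so the data hold no single-change step that could size the next one.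

Compound 3 `CC(=O)N(CCCCNC(=O)C1CSC(c2ccccc2O)=N1)CCCCNC(=O)C1CSC(c2ccccc2O)=N1` has not yet been measured in this assay. It keeps the rest of compound 2 and carries one change: acetyl in place of benzyl on an amine nitrogen. Neither measured compound shows what this exchange does on its own, so the expectation is only loosely anchored. It starts from compound 2 at 1000 nM and allows a modest loss of inhibition. The expected 2.5-fold higher number from compound 2 to compound 3 (0.40 log units; beyond the scatter) points toward a higher number, though it may not clear the scatter by much. The estimate for compound 3 is 2500 nM, with an expected range of 800 nM to 8000 nM.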

Compound 3, half-maximal inhibitory concentration in the P388 assay: 12000 nM
Beside the measured number, compound 3's estimate is 4.8-fold (0.68 log units) below it, and the stated range ends below it.
By their numbers in the P388 assay, from the lowest: compound 2; then compounds 3 and 1 (each within the scatter of the next).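

Within the data shown here, in the P388 assay compound 2 gives 1000 nM and compound 3 gives 12000 nM; acetyl in place of benzyl on an amine nitrogen gives a 12-fold higher number from compound 2 to compound 3 (1.08 log units; beyond the scatter), a large loss of inhibition and the first single-change step, which shows that the read-out is sensitive to the group at this position, at least for this pair. Among these compounds, in a physicochemical assay for solubility, in phosphate buffer, at pH 7.1 (on this read-out lower numbers stand for lower solubility and higher numbers for higher solubility), compound 2 gives 15000 nM and compound 3 gives 10000 nM; the same change gives a 1.5-fold lower number from compound 2 to compound 3 (0.18 log units; within the scatter), so solubility in phosphate buffer does not separate the two compounds, and the large step in inhibition has no counterpart in this read-out. No supporting data are available to explain the size of the inhibition step.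

The change removes an aromatic ring and brings in a carbonyl at once, and the compounds shown cannot say which of the two goes with the loss of inhibition. Benzoyl on the same amine nitrogen would keep both the ring and the carbonyl, while ethyl would carry neither, and the pair could begin to separate these two parts of the exchange.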